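A few compounds are considered here, and "the series" means these few. Any claim that something is new, unique, unknown or untested is made for them only; others in the source may bear on it.

Compound 1 `Cc1cc(Cl)c(-c2ncc[nH]2)cc1NC(=O)c1ccc(OCc2ccccn2)cc1`, compound 2 `Cc1cc(C)c(-c2ncc[nH]2)cc1NC(=O)c1ccc(OCc2ccccn2)cc1`, compound 3 `Cc1cc(C)c(-c2cn(C)cn2)cc1NC(=O)c1ccc(OCc2ccccn2)cc1`.

In a physicochemical assay for lipophilicity (on this read-out higher numbers stand for higher lipophilicity and lower numbers for lower lipophilicity), compound 2 gives 3.1 and compound 3 gives 3; the step of a number 0.10 log units lower from compound 2 to compound 3 (within the scatter) lies within the scatter, so these two sit level with each other. In this assay compound 1 gives > 3, which is a limit of the assay and not a number. Compound 4 `Cc1cc(F)c(-c2ncc[nH]2)cc1NC(=O)c1ccc(OCc2ccccn2)cc1` is not yet measured. It differs from compound 2 in one place: fluoro in place of methyl on an aromatic carbon. Within the data shown here, the only measured step at that place is a step that the limit leaves unreadable from compound 1 to compound 2; compound 1 sits at a limit (the limit of > 3 in this assay, at which 1 of the 3 values shown sits), so its size cannot be read. Among the measured compounds shown here, no measured step therefore gives the size of this change. Compound 4 is expected at 2.7, with a range from 2.3 to 3.1. The expected step is a number 0.40 log units lower from compound 2 to compound 4 (beyond the scatter).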

Compound 4, distribution coefficient: 3
For compound 4 the middle estimate is 0.30 log units below the measured one; the range from low to high includes it.
By their numbers in this assay, from the lowest: compounds 3, 4 and 2 (each within the scatter of the next).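

At the position ortho to the 1H-imidazol-2-yl group, this assay now gives a first readable step (a number 0.10 log units lower from compound 2 to compound 4 (within the scatter)), so with fluoro in place of methyl the two sit level. The steps that start from the chloro compound (among them a number no higher from compound 1 to compound 4 (the limit leaves the size open)) cannot be read: the limit of > 3 in this assay, at which 1 of the 4 values shown sits.

Going by these compounds, whether a methoxy group, a nitrile or a bare hydrogen at this position would also sit level with compound 2 stays open. On these data alone, how chloro compares in number with fluoro or methyl stays open too.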